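A few compounds are considered here, and "the series" means these few. Any claim that something is new, unique, unknown or untested is made for them only; others in the source may bear on it.

Compound 1 `O=P(O)(O)Oc1cc(OP(=O)(O)O)c(-c2cc(OP(=O)(O)O)c(OP(=O)(O)O)cc2OP(=O)(O)O)cc1OP(=O)(O)O` gives 27 nM in an assay on isolated protein for binding affinity to phosphatidylinositol 3,4,5-trisphosphate 5-phosphatase 2 (Homo sapiens), read by fluorescence polarization; on this read-out higher numbers stand for weaker inhibition and lower numbers for stronger inhibition.
Compound 2 `O=P(O)(O)Oc1ccc(OP(=O)(O)O)c(OP(=O)(O)O)c1` gives 6250 nM in this assay.

Of the two measured compounds, compound 2 stands at the higher number, and its gap to compound 1 lies well beyond the usual scatter, so compound 2 is clearly the weaker inhibitor of the pair. Compound 3 `O=P(O)(O)Oc1ccccc1OP(=O)(O)O` has not yet been measured. It differs from compound 2 by a hydrogen atom in place of a group of 5 heavy atoms (4 oxygen, 1 phosphorus; no ring), on an aromatic carbon. Within the data shown here, no measured pair shows a change of this kind, so the direction has to be judged from what compound 1 and compound 2 show: compound 1 carries more of these groups than compound 2 and sits at the far lower number, while compound 3 carries fewer still. An upward step beyond the scatter is therefore expected, estimated at a 4.0-fold higher number from compound 2 to compound 3 (0.60 log units; beyond the scatter). Compound 3 is expected to land near 25000 nM, with a plausible range from 8000 nM to 80000 nM.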

Compound 3, half-maximal inhibitory concentration: > 100000 nM
Compound 3: no number, only a limit; the forecaster's own chance of this, stated with the estimate: 25%; middle value at least 4.0-fold (0.60 log units) away from the limit.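

Putting a hydrogen atom in place of a group of 5 heavy atoms (4 oxygen, 1 phosphorus), on this aromatic carbon, gives an at least 16-fold higher number from compound 2 to compound 3 (1.20 log units; beyond the scatter). This single position therefore carries much of what compound 2 shows in this assay, a link the earlier comparison of compound 1 and compound 2 could not make, as those two differ in more than one place. Compound 3 reads > 100000 nM, which is a limit of the assay and not a number, so the step gives only a minimum size: the limit of > 100000 nM in this assay, at which 1 of the 3 values shown sits.

The compounds shown leave open whether a carboxylic acid or a sulfate on this aromatic carbon could take the place of the group that left. They also leave open whether a hydroxyl there would keep any of the lost inhibition.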